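The source may report more compounds than this note shows. Statements on the series, on what has been measured and on what is new or still open speak of the compounds shown alone.

Compound 1, `CC(C)n1nc(-c2ccon2)c2c(N)ncnc21`, in an assay on BaF3 cells for inhibition of proto-oncogene tyrosine-protein kinase receptor Ret (Homo sapiens), read by MTT assay, with a stated time of 48 h; on this read-out lower numbers stand for stronger inhibition of growth and higher numbers for weaker inhibition of growth: 3210 nM. Compound 2, `CC(C)n1nc(-c2cc(C(C)(C)C)on2)c2c(N)ncnc21`, in this assay: 6120 nM.

Among the compounds with values here, compound 2 gives the highest of the two numbers measured so far, yet its nearest neighbour is compound 1, and the step of a 1.9-fold higher number from compound 1 to compound 2 (0.28 log units; within the scatter) stays within the scatter, so the two cannot be ranked against each other. Compound 3, `CC(C)n1nc(-c2cc(-c3ccc(F)cc3)on2)c2c(N)ncnc21`, has not been measured. It differs from compound 2 by 4-fluorophenyl in place of tert-butyl on an aromatic carbon. Within the data shown here, the only measured step that concerns this position is a 1.9-fold higher number from compound 1 to compound 2 (0.28 log units; within the scatter), which shows that growing a group there from hydrogen to tert-butyl did not move the number beyond the scatter. Among the measured compounds shown here, no measured step tells what an aromatic ring in that place does. On this thin basis the step of a 1.4-fold lower number from compound 2 to compound 3 (0.13 log units; within the scatter) is expected to be small, with no clear direction. Compound 3 is therefore estimated at 4500 nM, within a range of 1500 nM to 14000 nM.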

Compound 3, concentration for 50% growth inhibition: > 10000 nM
Compound 3: no number, only a limit (the forecaster's own chance of this, stated with the estimate: 5%); middle value at least 2.2-fold (0.34 log units) away from the limit.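

Compound 3 carries a limit of the assay and not a number: the limit of > 10000 nM in this assay, at which 1 of the 3 values shown sits. Within the data shown here, with 4-fluorophenyl on this aromatic carbon, the series shows for the first time a change at this position that lies beyond the scatter, an at least 3.1-fold higher number from compound 1 to compound 3 (0.49 log units; beyond the scatter), whereas tert-butyl in place of hydrogen had stayed within it. Against tert-butyl itself, the exchange gives an at least 1.6-fold higher number from compound 2 to compound 3 (0.21 log units; that floor lies within the scatter), so the limit does not separate the ring-bearing group from tert-butyl, and only the comparison with hydrogen shows weaker inhibition of growth.

The compounds shown leave open whether this weaker inhibition follows from the aromatic ring or from its fluorine, which a plain phenyl would address. They also leave open what an amine or a carboxylic acid on this carbon would give.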